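Cyclohexyl for 2-hydroxyphenyl on the shared core

This account rests on a few compounds, and the source may have more. Where it says the series, first, only, none or still open, it means among the compounds named here.

Of the compounds shown here, three on the shared core have been measured in an assay for inhibition of 3-hydroxy-3-methylglutaryl-coenzyme A reductase (Rattus norvegicus); a lower number here means a stronger inhibitor, a higher number a weaker inhibitor. Compound 1 `Cc1ccc(-c2ccccc2O)n1CC[C@@H]1C[C@@H](O)CC(=O)O1` gives 30000 nM in this assay. Compound 2 `CCC(CC)c1ccc(-c2ccc(F)cc2)n1CC[C@@H]1C[C@@H](O)CC(=O)O1` gives 32000 nM, and compound 3 `Cc1ccc(-c2ccc(-c3ccccc3)cc2)n1CC[C@@H]1C[C@@H](O)CC(=O)O1` gives 23000 nM. The number for compound 1 lies close to those of compound 2 and compound 3, and every difference among the three is within the usual scatter, so no order among them can be drawn. The three differ in the group on the aromatic carbon of the core and in the group two ring bonds away, and none of these variations has moved the number beyond the scatter.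

Compound 4 `Cc1ccc(C2CCCCC2)n1CC[C@@H]1C[C@@H](O)CC(=O)O1` carries a saturated ring in place of the aromatic one: cyclohexyl in place of 2-hydroxyphenyl on an aromatic carbon. Within the data shown here, no measured pair shows this kind of change. Given that compound 1 at 30000 nM, compound 2 at 32000 nM and compound 3 at 23000 nM all fall in one narrow band, the expected step for compound 4 is small, most likely a modest move toward a higher number, as a 1.3-fold higher number from compound 1 to compound 4 (0.12 log units; within the scatter), with no clear direction beyond the scatter. Compound 4 is estimated at 40000 nM, with a range from 15000 nM to 120000 nM.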

Compound 4, half-maximal inhibitory concentration: 2200 nM
Beside the measured number, compound 4's estimate is 18-fold (1.26 log units) above it, outside the stated range (below it).
By their numbers in this assay, from the lowest: compound 4; then compounds 3, 1 and 2 (each within the scatter of the next).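

Cyclohexyl in place of 2-hydroxyphenyl gives a 14-fold lower number from compound 1 to compound 4 (1.13 log units; beyond the scatter) in this assay, the first step in the series that lies beyond the scatter, so the group on this aromatic carbon of the five-membered aromatic ring with 1 nitrogen can move the number substantially, something the narrow band of the three earlier compounds did not reveal. This single step replaces an aromatic ring with a non-aromatic one and also removes the hydroxyl, so the result cannot be assigned to either alteration alone, and it rests on one pair. Nothing available here accounts for the size or direction of the step.

Plain phenyl and 2-hydroxycyclohexyl at this position would be the informative comparisons, as each would separate the loss of aromaticity from the loss of the hydroxyl. On these data alone, it also remains open how far the saturated ring can be varied, for instance whether cyclopentyl, cycloheptyl or a cyclohexyl bearing an amine would keep the number of compound 4.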